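From a substituted phenyl to plain phenyl on the carbonyl

The compounds below may be only part of what the source reports. "The series", "measured", "known", "first", "only" and "open" are said of these compounds alone.

Measured in a functional assay on T47D cells (Homo sapiens) for inhibition, read by sulforhodamine B assay, with a stated time of 48 h; a lower number here means that less compound is tolerated, a higher number that more compound is tolerated:
- compound 1 `COc1cc(-c2nn(-c3cccc(NC(=O)Nc4cccc(C(F)(F)F)c4)c3)cc2-c2ccncc2)ccc1Cl`: 50000 nM
- compound 2 `COc1cc(-c2nn(-c3cccc(NC(=O)c4ccc(Cl)c(C(F)(F)F)c4)c3)cc2-c2ccncc2)ccc1Cl`: > 32500 nM (a limit of the assay, not a number)

Compound 2 has no exact value, only the limit (> 32500 nM). The next compound, compound 3 `COc1cc(-c2nn(-c3cccc(NC(=O)c4ccccc4)c3)cc2-c2ccncc2)ccc1Cl`, has phenyl in place of 4-chloro-3-(trifluoromethyl)phenyl on a carbonyl carbon. This carbonyl carbon also carries an amide-type nitrogen.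

Going by the values given here, only one measured step bears on this change, as it also swaps the group on that carbonyl carbon (a step that the limit leaves unreadable from compound 1 to compound 2). Its size cannot be read, and the limit is what hides it (the limit of > 32500 nM in this assay, at which 1 of the 2 values shown sits). That leaves no measured guide to the direction of a change, so no step beyond the scatter is expected in this assay. Among the compounds with values here, the one exact number is for compound 1 (50000 nM), and compound 3 is expected to lie in that same region.

The expected step is small (a step that the limit leaves unreadable from compound 2 to compound 3). For compound 3 the estimated value is 40000 nM within an expected range of 15000 nM to 100000 nM. Compound 3 may well be expected to yield only a limit rather than an exact number.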

Compound 3, concentration lethal to 50% of the cells: > 100000 nM
Compound 3: a limit, no number; the forecaster's own chance of this, stated with the estimate: 55%; middle value at least 2.5-fold (0.39 log units) from the limit.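

In this assay compound 3, with phenyl on the carbonyl carbon, gives > 100000 nM, which is a limit of the assay and not a number. Going by these compounds alone, compound 2 also has only a limit, so the step from it to compound 3 cannot be read, because neither side of this change has an exact value: the limit of > 32500 nM in this assay, at which 1 of the 3 values shown sits. The one step that can be read, with phenyl in place of (3-(trifluoromethyl)phenyl)amino on the carbonyl carbon, is an at least 2.0-fold higher number from compound 1 to compound 3 (0.30 log units; that floor lies within the scatter), which shows no fall in the number at this position, although the floor of the step does not clear the scatter.

Going by these compounds, what the chlorine and the trifluoromethyl on the phenyl each contribute remains open, as the pair that differs by these groups has no exact numbers. On these data alone, it is also open whether another group on this carbonyl carbon, such as a ring carrying an amine or a carboxylic acid, or a longer chain, would give an exact value well under the numbers seen so far in this assay.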